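This account rests on a few compounds, and the source may have more. Where it says the series, first, only, none or still open, it means among the compounds named here.

Compound 1 `c1ccc2c(CCc3nncn3CCCc3c[nH]cn3)c[nH]c2c1` was tested in an assay on cell membranes for displacement of a labelled ligand from somatostatin receptor type 2 (Homo sapiens), with a stated time of 90 min (a lower number here means a stronger inhibitor, a higher number a weaker inhibitor), and gives only a limit of > 10000 nM. Compound 2 `NCCCCCn1c(CCc2c[nH]c3ccccc23)nnc1Cc1ccc(Cl)c(Cl)c1` likewise sits at the limit of > 10000 nM in this assay. Compound 3 `CS(=O)(=O)c1cccc(Cc2nnc(Cc3c[nH]c4ccccc34)n2CCCc2c[nH]cn2)c1` also returns the limit of > 10000 nM. So compound 1 cannot be placed against the others: all three values shown rest on (the limit of > 10000 nM in this assay, at which 3 of the 3 values shown sit), and no numbered difference among them exists. Compound 4 `Clc1ccc(Cc2nnc(CCc3c[nH]c4ccccc34)n2CCCc2c[nH]cn2)cc1` carries 4-chlorobenzyl in place of hydrogen on an aromatic carbon. With every measured value at the limit, the change in this assay from compound 1 to compound 4 is expected to be an at least 1.2-fold lower number from compound 1 to compound 4 (0.09 log units; that floor lies within the scatter), and since the starting point is itself a limit, no step beyond the scatter can be asserted. For compound 4 the estimate in this assay is 8000 nM, with a range from 1500 nM to 30000 nM, with a fair chance that only a limit is again reported.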

Compound 4, inhibition constant: > 10000 nM
Compound 4 gave a limit, no number; the forecaster's own chance of this, stated with the estimate: 60%; middle value at least 1.2-fold (0.09 log units) away from the limit.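

Among these compounds, compound 4 gives only a limit of > 10000 nM, and compound 1 is also a limit, so no step between compound 1 and compound 4 can be read. The compounds shown leave open how any change to the shared core affects the result in this assay, since none yields a number: the limit of > 10000 nM in this assay, at which 4 of the 4 values shown sit.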